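The source may hold more compounds than are shown below. What is called first, only, known or untested is meant among the compounds shown, and "the series" means these compounds.

Measured compounds:
Compound 1, `O=C(CCCCCCCN1C(=O)c2ccccc2C1=O)NO`, gives 71.4 nM.
Compound 2, `O=C(CCCCCCC(=O)c1ccccc1)NO`, gives 500 nM.
Compound 3, `O=C(CCCCCCCC(=O)c1ccc(C(F)(F)F)cc1)NO`, gives 45 nM.

These three numbers come from an assay on isolated protein for inhibition of histone deacetylase 8 (Homo sapiens); a higher number here means a weaker inhibitor, a lower number a stronger inhibitor. Among them compound 3 has the lowest number. Its nearest neighbour is compound 1, and the gap between the two lies within the scatter of repeated measurements, so the two cannot be told apart. Compound 2 stands furthest away, with a gap that does lie beyond the scatter.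

Compound 4, `O=C(CCCCCCCC(=O)c1ccc(-c2ccc(Br)cc2)cc1)NO`, has not yet been measured. It differs from compound 3 in one place: 4-bromophenyl in place of trifluoromethyl on an aromatic carbon. Among the compounds with values here, no step between measured compounds mirrors this change, so there is no direct precedent in this set. The expectation is a small move toward a lower number, of a size close to the scatter, so that a result near that of compound 3 would not be surprising. For compound 4 the estimated value in this assay is 30 nM, with a range from 8 nM to 120 nM. This estimate corresponds to a step of a 1.5-fold lower number from compound 3 to compound 4 (0.18 log units; within the scatter).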

Compound 4, half-maximal inhibitory concentration: 2 nM
Compound 4: the middle estimate sits 15-fold (1.18 log units) above what was measured; measured number below the stated range.
By their numbers in this assay, from the lowest: compound 4; then compounds 3 and 1 (each within the scatter of the next); then compound 2.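

In this assay, putting 4-bromophenyl in place of trifluoromethyl on the aromatic carbon gives a 23-fold lower number from compound 3 to compound 4 (1.35 log units; beyond the scatter) and so shows that this position tolerates more than a small group. A group of 7 heavy atoms carrying its own six-membered aromatic ring replaces one of 4 heavy atoms with no ring, and the number falls rather than rises. The earlier compounds could not show this, as no two of them differ in one place only, and no measurement here explains the size of this step.

Going by these compounds, it remains open whether the step depends on the second ring or on its bromine, which a plain phenyl group on the same aromatic carbon would help separate. A 4-methoxyphenyl or 4-aminophenyl group there would show how far other groups on that second ring shift the number.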